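The source may hold more compounds than are shown below. What is called first, only, known or untested is meant among the compounds shown, and "the series" means these compounds.

Three compounds built on one shared core have been run through an ADME assay on microsomes from liver (Rattus norvegicus) for metabolic stability, read by LC-MS; a higher number here means faster removal of the compound, a lower number slower removal. Compound 1 `COc1cc(N2CCN(C(=O)Cn3cnc4cccc(C(F)(F)F)c43)CC2)ccc1-c1cnc(C)o1` gives 7 mL.min-1.g-1 in this assay, compound 2 `COc1cc(C2CCN(C(=O)N[C@@H](C)c3cccc4ccccc34)CC2)ccc1-c1cnc(C)o1` gives 170 mL.min-1.g-1, and compound 3 `COc1cc(N2CCN(C(=O)Cn3ncc4ccccc43)CC2)ccc1-c1cnc(C)o1` gives 77 mL.min-1.g-1. Among these three numbers compound 3 stands second highest: compound 2 is above it by a margin beyond the usual scatter, while compound 1 is well below it, also beyond the scatter.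

The next compound, compound 4 `COc1cc(N2CCN(C(=O)Cn3cnc4ccccc43)CC2)ccc1-c1cnc(C)o1`, keeps every atom of compound 3 but joins them differently: 1H-benzimidazol-1-yl in place of 1H-indazol-1-yl on a saturated chain carbon bound to a carbonyl carbon. In plain words, a 1H-benzimidazol-1-yl group takes the place of a 1H-indazol-1-yl group on the saturated chain carbon bound to the carbonyl.

Within the data shown here, no measured pair shows exactly this exchange, so there is no step to lean on. Among the measured compounds shown here, the only other compound that carries a 1H-benzimidazol-1-yl group is compound 1, which gives 7 mL.min-1.g-1, a low number in this assay, though compound 1 differs from compound 4 in a further place as well. On that thin basis a move toward slower removal is expected for compound 4, estimated at 40 mL.min-1.g-1, with a range from 15 mL.min-1.g-1 to 100 mL.min-1.g-1. The expected step is a 1.9-fold lower number from compound 3 to compound 4 (0.28 log units; within the scatter), and it may turn out no larger than the scatter.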

Compound 4, intrinsic clearance in microsomes: 22 mL.min-1.g-1
The estimate for compound 4 lay 1.8-fold (0.26 log units) above the measured number, within the range that was stated.
By their numbers in this assay, from the lowest: compound 1; then compound 4; then compound 3; then compound 2.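

In this assay, the exchange of 1H-indazol-1-yl for 1H-benzimidazol-1-yl on the saturated chain carbon bound to a carbonyl carbon gives a 3.5-fold lower number from compound 3 to compound 4 (0.54 log units; beyond the scatter) and so lies beyond the scatter, even though the two groups have the same atoms and the same counted features; at this position, how those atoms are joined matters to the read-out. Among these compounds, compound 4 also gives the first clean look at the trifluoromethyl group, since hydrogen in place of trifluoromethyl on an aromatic carbon gives a 3.1-fold higher number from compound 1 to compound 4 (0.50 log units; beyond the scatter), which shows that the 1H-benzimidazol-1-yl group alone does not reach the low number of compound 1 and that this second change counts as well. Nothing available explains why either exchange moves the number.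

Still open, on these data alone, is whether trifluoromethyl on the 1H-indazol-1-yl group would bring a step of similar size, and whether a chlorine or a methoxy on that aromatic carbon would act as trifluoromethyl does. Also open, as far as these compounds go, is how a 1H-indol-1-yl group would read on the same saturated chain carbon.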